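A few compounds are considered here, and "the series" means these few. Any claim that something is new, unique, unknown or untested is made for them only; others in the source may bear on it.

Working notes on the series. Two compounds sharing one core have numbers in an assay on isolated protein for inhibition of tyrosine-protein kinase receptor UFO (Homo sapiens), read by FRET and Z'-LYTE, with a stated time of 1.5 h; a higher number here means a weaker inhibitor, a lower number a stronger inhibitor. Compound 1 `Cc1c(C(=O)Nc2ccc(Oc3ncnc4[nH]cc(-c5ccccc5)c34)c(F)c2)c(=O)c2cc(C(F)(F)F)ccc2n1C` gives 150 nM. Going by the values given here, compound 2 `CCc1ccc2c(c1)c(=O)c(C(=O)Nc1ccc(Oc3ncnc4[nH]cc(-c5ccccc5)c34)c(F)c1)c(C)n2C` gives 6 nM and so stands with the lowest of the two numbers; the single measured step is a 25-fold lower number from compound 1 to compound 2 (1.40 log units; beyond the scatter), ethyl in place of trifluoromethyl on an aromatic carbon.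

Compound 3 `CCc1ccc2c(c1)c(=O)c(C(=O)Nc1ccc(Oc3ncnc4[nH]cc(-c5ccccc5)c34)c(C)c1)c(C)n2C` differs from compound 2 by methyl in place of fluoro on an aromatic carbon. Among the compounds with values here, no measured step bears on this change: the one known step alters the ethyl group and leaves the fluoro untouched, so the size of the change from fluoro to methyl at this place has no precedent. With nothing to point either way, the expected step is a 1.3-fold higher number from compound 2 to compound 3 (0.12 log units; within the scatter), that is no change beyond the scatter in this assay. For compound 3 the estimated value in this assay is 8 nM, with a range of 3 nM to 25 nM.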

Compound 3, half-maximal inhibitory concentration: 1120 nM
Beside the measured number, compound 3's estimate is 140-fold (2.15 log units) below it, and the stated range ends below it.
By their numbers in this assay, from the lowest: compound 2; then compound 1; then compound 3.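

In this assay, this place on an aromatic carbon, ortho to a large group and meta to a large group, turns out to be highly sensitive: methyl in place of fluoro gives a 190-fold higher number from compound 2 to compound 3 (2.27 log units; beyond the scatter). The exchange swaps one heavy atom for one heavy atom, with no ring, hydrogen-bond donor, hydrogen-bond acceptor or net charge on either side, and yet, alongside a 25-fold lower number from compound 1 to compound 2 (1.40 log units; beyond the scatter), it marks a second place in the series where a single change moves the number beyond the scatter. Nothing on hand accounts for the size of this step.

As far as these compounds go, whether the loss is specific to methyl stays open, and a chlorine atom, a methoxy group or plain hydrogen at this place would help to settle it. Also open, from the compounds shown here alone, is whether the step from trifluoromethyl to ethyl keeps its size with methyl at this place.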